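The source may report more compounds than this note shows. Statements on the series, on what has been measured and on what is new or still open speak of the compounds shown alone.

Compound 1 `O=C(Nc1ccc(F)cc1)Nc1cccc(CNc2ncnc3ccccc23)c1` gives 21000 nM in a functional assay on A549 cells (Homo sapiens) for antiproliferative activity, read by MTT assay; on this read-out higher numbers stand for weaker inhibition and lower numbers for stronger inhibition. Compound 2 `COc1cc2ncnc(NCc3cccc(NC(=O)Nc4ccccc4C)c3)c2cc1OC` gives 21400 nM in this assay, and compound 3 `COc1cc2ncnc(NCc3cccc(NC(=O)Nc4cccc(C)c4)c3)c2cc1OC` gives 27100 nM in this assay. The one single-point step among these, a 1.3-fold higher number from compound 2 to compound 3 (0.10 log units; within the scatter), is the only measured change at the urea-bearing aryl group. All three numbers lie within the scatter of one another, so compound 3 is not set apart from compound 1 or compound 2 on this assay.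

Compound 4 `COc1ccccc1NC(=O)Nc1cccc(CNc2ncnc3cc(OC)c(OC)cc23)c1` is reached from compound 3 by 2-methoxyphenyl in place of 3-methylphenyl on an amide-type nitrogen. For the measured compounds named here, the only measured step at this place is a 1.3-fold higher number from compound 2 to compound 3 (0.10 log units; within the scatter), which shifted a methyl group around the same ring and stayed within the scatter. Going by the values given here, no measured pair exchanges methyl for methoxy here, so the expectation rests on that single step alone and carries a wide range. For compound 4 in this assay the expected step is a 1.1-fold lower number from compound 3 to compound 4 (0.04 log units; within the scatter), nothing beyond the scatter, with an estimate of 25000 nM and a range from 9000 nM to 70000 nM.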

Compound 4, half-maximal inhibitory concentration: 15200 nM
Compound 4: the middle estimate sits 1.6-fold (0.22 log units) above what was measured; measured number inside the range.
By their numbers in this assay, from the lowest: compounds 4, 1, 2 and 3 (each within the scatter of the next).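

In this assay, the replacement of 3-methylphenyl by 2-methoxyphenyl on the amide-type nitrogen gives a 1.8-fold lower number from compound 3 to compound 4 (0.25 log units; within the scatter), and the exchange of methyl for methoxy on an aromatic carbon gives a 1.4-fold lower number from compound 2 to compound 4 (0.15 log units; within the scatter). For the compounds shown here, the second step is the only measured exchange of methyl for methoxy on this ring, and it shows that the oxygen-bearing substituent, like the shifted methyl group, leaves the number within the scatter, so the three aryl ureas compound 2, compound 3 and compound 4 are not told apart. Nothing measured here bears on the reason for these numbers.

On these data alone, whether a carboxylic acid, an amine or a longer alkoxy chain in place of methoxy would carry the number beyond the scatter remains open. Also open, as far as these compounds go, is what the methoxy groups on the shared core contribute, since compound 1 differs from compound 2, compound 3 and compound 4 in more than one place.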